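The compounds below may be only part of what the source reports. "The series", "measured", "known", "first", "only" and "open" are said of these compounds alone.

Working notes on the series. a physicochemical assay for solubility, with a stated time of 18 h, at pH 7.4 (a lower number here means a less soluble compound, a higher number a more soluble compound), has been run on three compounds of the shared core. Compound 1 `COc1ccc(-c2ccc3c(NCCCNCc4cccc(OC)c4O)ccnc3c2)cc1` gives 32000 nM, compound 2 `COc1cccc(CNCCCNc2ccnc3cc(C4CCCCC4)ccc23)c1O` gives 4200 nM, and compound 3 `COc1cccc(Oc2ccc3c(NCCCNCc4cc(F)ccc4OC)ccnc3c2)c1` gives 14500 nM. On these numbers compound 3 stands second highest of the three, nearer to compound 1 than to compound 2. Within the data shown here, the only single-point step measured so far is a 7.6-fold lower number from compound 1 to compound 2 (0.88 log units; beyond the scatter), which changes a different part of the molecule from the one at issue here.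

Compound 4 `COc1cccc(Oc2ccc3c(NCCCNCc4cccc(OC)c4O)ccnc3c2)c1` is not yet measured. It differs from compound 3 by 2-hydroxy-3-methoxyphenyl in place of 5-fluoro-2-methoxyphenyl on a saturated chain carbon bound to an amine nitrogen. Among the measured compounds shown here, no measured step bears on this change; compound 1 and compound 3 differ in this same group, but also in the group on the aromatic carbon, so their two values can only be read as what they show. The step from compound 3 to compound 4 is therefore expected to be small, a 1.2-fold higher number from compound 3 to compound 4 (0.09 log units; within the scatter), with no confident direction. Compound 4 is expected to give about 18000 nM, between 7000 nM and 45000 nM.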

Compound 4, solubility: 14500 nM
Compound 4: middle estimate off by 1.2-fold (0.09 log units), on the high side; low and high end bracket the measured number.
By their numbers in this assay, from the lowest: compound 2; then compounds 3 and 4 (each within the scatter of the next); then compound 1.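

In this assay, the change on the saturated chain carbon bound to an amine nitrogen gives no change at the digits printed from compound 3 to compound 4 (within the scatter), so with 3-methoxyphenoxy on the aromatic carbon, 2-hydroxy-3-methoxyphenyl and 5-fluoro-2-methoxyphenyl cannot be told apart here. With 2-hydroxy-3-methoxyphenyl held on that chain carbon, the group on the aromatic carbon can now be read on its own: 3-methoxyphenoxy in place of cyclohexyl gives a 3.5-fold higher number from compound 2 to compound 4 (0.54 log units; beyond the scatter), and 3-methoxyphenoxy in place of 4-methoxyphenyl gives a 2.2-fold lower number from compound 1 to compound 4 (0.34 log units; beyond the scatter). Nothing at hand gives a reason for any of these steps.

Among the compounds shown, the chain-carbon change is seen only with 3-methoxyphenoxy on the aromatic carbon, so its size with cyclohexyl or 4-methoxyphenyl there remains open. Also open, on these data alone, is how a morpholine or a carboxylic acid on that chain carbon would read in this assay.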